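This account rests on a few compounds, and the source may have more. Where it says the series, first, only, none or still open, it means among the compounds named here.

Measured so far in a functional assay on COLO 205 cells (Homo sapiens) for cytotoxicity, read by MTT assay, with a stated time of 24 h; a lower number here means a stronger inhibitor, a higher number a weaker inhibitor:
- compound 1 `FC(F)(F)Oc1ccc(-c2cc(COc3ccccc3-c3nc4ccccc4s3)on2)cc1`: 19900 nM
- compound 2 `c1ccc(-n2cc(COc3ccccc3-c3nc4ccccc4s3)nn2)cc1`: 16600 nM
- compound 3 `Fc1ccccc1-c1cc(COc2ccccc2-c2nc3ccccc3s2)on1`: 18300 nM

All three compounds share one core and differ only in the aryl group attached to the five-membered ring, or in the five-membered ring itself. On the numbers shown, compound 3 sits in the middle of the three, yet the spread is small: a 1.1-fold lower number from compound 1 to compound 3 (0.04 log units; within the scatter), and compound 2, for which no single-point step to compound 3 is defined, gives a number that likewise lies within the scatter of the value of compound 3. So far nothing in this assay separates the three.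

Compound 4 `Cc1ccc(-c2cc(COc3ccccc3-c3nc4ccccc4s3)on2)cc1` is the next member, not yet measured in this assay. It differs from compound 3 by 4-methylphenyl in place of 2-fluorophenyl on an aromatic carbon. Going by the values given here, the only measured step that bears on this change is the aryl swap at the same place from compound 1 to compound 3, which was within the scatter. Another aryl swap at that place is therefore expected to give no step beyond the scatter in this assay: the estimated change is a 1.0-fold lower number from compound 3 to compound 4 (0.01 log units; within the scatter). Compound 4 is estimated at 18000 nM, with a range from 9000 nM to 36000 nM.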

Compound 4, half-maximal inhibitory concentration: 14200 nM
Compound 4: the middle estimate sits 1.3-fold (0.10 log units) above what was measured, within the range that was stated.
By their numbers in this assay, from the lowest: compounds 4, 2, 3 and 1 (each within the scatter of the next).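

In this assay, a third aryl group at the aromatic carbon next to the ring nitrogen adds a second and a third step at this place: 4-methylphenyl in place of 2-fluorophenyl gives (a 1.3-fold lower number from compound 3 to compound 4 (0.11 log units; within the scatter)), and methyl in place of trifluoromethoxy gives (a 1.4-fold lower number from compound 1 to compound 4 (0.15 log units; within the scatter)). The second of these is the first change shown that keeps the phenyl ring and alters only the group in its 4-position, and it too stays within the scatter, so 2-fluorophenyl, 4-(trifluoromethoxy)phenyl and 4-methylphenyl cannot be told apart at this place. No independent measurement bears on this outcome, and it can be reported only as an absence of separation among these three groups.

The compounds shown leave open whether any group at this place gives a step beyond the scatter, for instance an amine or a carboxylic acid on the phenyl ring, or a longer chain in place of the methyl of compound 4. Among them, compound 2 also has no partner carrying the same aryl group on the five-membered ring of compound 3, so the contribution of that ring remains unresolved.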